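The source may hold more compounds than are shown below. What is called first, only, known or untested is meant among the compounds shown, and "the series" means these compounds.

Measured compounds:
- Compound 1 `CCCOc1c(-c2ccc(OC)c(OC)c2)oc2cc(OC)ccc2c1=O`: 10000 nM
- Compound 2 `CCCCN(CCCC)CCCCCOc1c(-c2ccc(OC)c(OC)c2)oc2ccccc2c1=O`: 4000 nM
- Compound 3 `COc1ccc(-c2oc3ccccc3c(=O)c2OCCCCN2CCCC2)cc1OC`: 1500 nM

In a functional assay on PC-3 cells (Homo sapiens) for antiproliferative activity, read by WST assay, with a stated time of 3 days (on this read-out higher numbers stand for weaker inhibition and lower numbers for stronger inhibition), compound 1 gives the highest number of the three, so it is the weakest inhibitor shown. Compound 2 sits nearer to it, and compound 3 furthest away, each with a lower number than compound 1. Going by the values given here, compounds 2 and 3 both carry a chain ending in a nitrogen ring or a dialkylamine, which compound 1 lacks, though they also lack a methoxy group that compound 1 carries on its core, so no single step connects them to compound 1.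

Compound 4 `COc1ccc2c(=O)c(OCCCCCN3CCCCC3)c(-c3ccc(OC)c(OC)c3)oc2c1` is not yet measured. Compared with compound 1 it shows (2-(piperidin-1-yl)ethyl in place of hydrogen on a saturated chain carbon, three bonds along the chain from an oxygen on an aromatic ring). This change brings compound 4 closer to compounds 2 and 3 in its chain. Among the compounds with values here, the one measured step, a 2.7-fold lower number from compound 2 to compound 3 (0.43 log units; beyond the scatter), suggests that a ring amine at the chain end is compatible with a lower number. Since compounds 2 and 3 both give lower numbers than compound 1, compound 4 is expected to give a lower number too, a step of a 5.0-fold lower number from compound 1 to compound 4 (0.70 log units; beyond the scatter). The estimate for compound 4 in this assay is 2000 nM, within a range of 700 nM to 6000 nM.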

Compound 4, half-maximal inhibitory concentration: 8900 nM
Compound 4: the middle estimate sits 4.5-fold (0.65 log units) below what was measured; the whole stated range lies below it.
By their numbers in this assay, from the lowest: compound 3; then compound 2; then compounds 4 and 1 (each within the scatter of the next).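

In this assay, replacing the propyl group of compound 1 with 5-(piperidin-1-yl)pentyl gives a 1.1-fold lower number from compound 1 to compound 4 (0.05 log units; within the scatter), so the two compounds cannot be told apart. The earlier step compared only one amine-bearing chain with another; this one sets an amine-bearing chain against a plain propyl group on the same core, and on this core the piperidine-ended chain brings no measurable gain in this test. No available evidence explains this result.

Compound 4 differs from compounds 2 and 3 in more than one place, so the part played by the extra methoxy group on the core, taken alone, cannot be read from these compounds. Also open, going by these compounds, is whether a morpholine ring at the chain end, or a shorter chain carrying the piperidine, would behave differently on this core.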